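Three Measured Compounds and a Fluoro Analogue Awaiting Its Value

This account rests on a few compounds, and the source may have more. Where it says the series, first, only, none or still open, it means among the compounds named here.

Compound 1 `O=C(O)c1ccc(OCc2ccccc2)cc1O`: > 40000 nM
Compound 2 `O=C(O)c1ccc(OCc2ccc(F)cc2)cc1O`: > 40000 nM
Compound 3 `O=C(NCc1ccc(F)cc1)c1cccc(O)c1O`: > 40000 nM

All three were tested in an ADME assay on NCI-H630 cells (Homo sapiens) for cytotoxicity, read by MTT assay, with a stated time of 72 h; on this read-out lower numbers stand for higher toxicity in this test and higher numbers for lower toxicity in this test. Compound 1 gives > 40000 nM, which is a limit of the assay and not a number. Compound 2 likewise gives > 40000 nM, again a limit. Compound 3 gives > 40000 nM, also a limit. From compound 1 to compound 2 the change is fluoro in place of hydrogen on an aromatic carbon, and the step is a step that the two limits leave unreadable from compound 1 to compound 2 because of the limit of > 40000 nM in this assay, at which 3 of the 3 values shown sit.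

Compound 4 `O=C(NCc1ccc(F)c(F)c1)c1cccc(O)c1O` is not yet measured. It differs from compound 3 by fluoro in place of hydrogen on an aromatic carbon, the same kind of change as that from compound 1 to compound 2, though the surroundings differ: in compound 2 the fluoro sits para to a large group, in compound 4 it sits ortho to a fluoro group and meta to a large group. How the core of compound 1 differs from that of compound 3 is not broken down here.

Compound 4 is expected in this assay to give 60000 nM, somewhere from 25000 nM to 200000 nM, most likely as a limit again. The expected step that the limit leaves unreadable from compound 3 to compound 4 rests on compound 3 giving > 40000 nM and on the unreadable earlier step that the two limits leave unreadable from compound 1 to compound 2.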

Compound 4, half-maximal cytotoxic concentration: > 40000 nM
Compound 4: a limit, no number (the forecaster's own chance of this, stated with the estimate: 85%); the middle value does not contradict the limit.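

In this assay no step can be read from compound 3 to compound 4, because both compounds give a limit and not a number: the limit of > 40000 nM in this assay, at which 4 of the 4 values shown sit.

The compounds shown leave open at what concentration any of the four would turn toxic in this assay, and whether fluoro in place of hydrogen on an aromatic carbon changes that concentration at all.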